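The compounds below may be only part of what the source reports. "The series", "measured", "known", "first", "only" and "open" are said of these compounds alone.

In an assay on isolated protein for binding affinity to 5-hydroxytryptamine receptor 1B (Rattus norvegicus) (on this read-out higher numbers stand for weaker inhibition and lower numbers for stronger inhibition), compound 1 `c1ccc2c(c1)CC2CN1CCN(c2cccc3c2OCCO3)CC1` gives 214 nM, while compound 2 `c1ccc2c(c1)CC2CCCN1CCN(c2cccc3c2OCCO3)CC1` gives 646 nM. Going by the values given here, compound 2 thus holds the higher of the two numbers so far, and its gap to compound 1 lies beyond the scatter. Compound 3 `c1ccc2c(c1)CC2CCCCN1CCN(c2cccc3c2OCCO3)CC1` differs from compound 2 by a group of 9 heavy atoms (9 carbon; one four-membered non-aromatic ring of carbon only, one six-membered aromatic ring of carbon only) in place of a group of 8 heavy atoms (8 carbon; one four-membered non-aromatic ring of carbon only, one six-membered aromatic ring of carbon only), on a saturated chain carbon, three bonds along the chain from an amine nitrogen in a ring. Among the compounds with values here, no measured pair shows this exact change, so only a guarded expectation is possible: the expected step, a 1.4-fold higher number from compound 2 to compound 3 (0.14 log units; within the scatter), is small and toward a higher number, probably within the scatter. For compound 3 the estimate in this assay is 900 nM, with a range from 300 nM to 2700 nM.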

Compound 3, inhibition constant: 631 nM
Estimate against measurement, compound 3: 1.4-fold (0.15 log units) above; the range from low to high includes it.
By their numbers in this assay, from the lowest: compound 1; then compounds 3 and 2 (each within the scatter of the next).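

In this assay, the group of 9 heavy atoms in place of the group of 8 heavy atoms, on a saturated chain carbon, three bonds along the chain from an amine nitrogen in a ring, gives a 1.0-fold lower number from compound 2 to compound 3 (0.01 log units; within the scatter). At this position, this change therefore leaves compound 2 and compound 3 indistinguishable on this read-out. No supporting evidence bears on this result.
Still open, as far as these compounds go, is whether a longer chain than that of compound 3 would also stay within the scatter of it. Also open, from the compounds shown here alone, is how a hydroxyl group or an amide on this chain would read.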